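The source may hold more compounds than are shown below. What is called first, only, known or untested is meant among the compounds shown, and "the series" means these compounds.

In a functional assay on HL-60 cells (Homo sapiens) for cytotoxicity, read by MTT assay, with a stated time of 96 h (on this read-out lower numbers stand for stronger inhibition and higher numbers for weaker inhibition), three compounds built on a shared core have been measured. Compound 1 `CC[C@H](N)C(=O)N[C@@H]1C(=O)N2[C@@H](CC[C@@H]1CNC(=O)NCc1ccccc1)CC[C@H]2C(=O)NC(c1ccccc1)c1ccccc1` gives 51000 nM, compound 2 `CC[C@H](N)C(=O)N[C@@H]1C(=O)N2[C@@H](CC[C@@H]1CCNC(=O)c1ccccc1)CC[C@H]2C(=O)NC(c1ccccc1)c1ccccc1` gives 50700 nM, and compound 3 `CCNCC[C@H]1CC[C@H]2CC[C@@H](C(=O)NC(c3ccccc3)c3ccccc3)N2C(=O)[C@H]1NC(=O)[C@@H](N)CC` gives 62800 nM. Compound 3 therefore lies within the scatter of both other compounds. Compound 4 `CC[C@H](N)C(=O)N[C@@H]1C(=O)N2[C@@H](CC[C@@H]1CCNCc1ccccc1)CC[C@H]2C(=O)NC(c1ccccc1)c1ccccc1` differs from compound 3 by one change: phenyl in place of methyl on a saturated chain carbon bound to an amine nitrogen. This places phenyl in place of methyl on a saturated chain carbon bound to an amine nitrogen, turning ethylamino into benzylamino. The closest evidence is a 1.2-fold higher number from compound 2 to compound 3 (0.09 log units; within the scatter), where ethyl replaces benzoyl on an amine nitrogen. The other two measured steps, a 1.2-fold higher number from compound 1 to compound 3 (0.09 log units; within the scatter) and a 1.0-fold lower number from compound 1 to compound 2 (0.00 log units; within the scatter), also stay within the scatter. Side chains with and without a phenyl ring thus read alike across these three compounds, and none of them goes against this. No step beyond the scatter is therefore expected in this assay. The expected step is a 1.1-fold lower number from compound 3 to compound 4 (0.06 log units; within the scatter). Compound 4 is estimated at 55000 nM, with an expected range from 28000 nM to 100000 nM.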

Compound 4, half-maximal inhibitory concentration: 15400 nM
Beside the measured number, compound 4's estimate is 3.6-fold (0.55 log units) above it, and the stated range ends above it.
By their numbers in this assay, from the lowest: compound 4; then compounds 2, 1 and 3 (each within the scatter of the next).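

In this assay, phenyl in place of methyl on a saturated chain carbon bound to an amine nitrogen gives a 4.1-fold lower number from compound 3 to compound 4 (0.61 log units; beyond the scatter) and so opens the first separation among these compounds. A phenyl ring is not enough on its own, as compound 1 and compound 2 also carry one: benzyl in place of benzoyl on the amine nitrogen gives a 3.3-fold lower number from compound 2 to compound 4 (0.52 log units; beyond the scatter) and (benzylamino)methyl in place of (benzylcarbamoyl)amino gives a 3.3-fold lower number from compound 1 to compound 4 (0.52 log units; beyond the scatter) in the same direction. Only the benzylamino side chain, with a phenyl ring and no carbonyl on that nitrogen, stands apart, and nothing measured here accounts for this.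

The compounds shown leave open whether a longer chain such as phenethyl on the amine nitrogen would keep this step. They also leave open how a chlorine or a methoxy group on the phenyl ring of the benzyl would read.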